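Taking the 2-fluorobenzyl group off compound 2

The source may hold more compounds than are shown below. What is called first, only, known or untested is meant among the compounds shown, and "the series" means these compounds.

Compound 1 `COc1ccc(COc2c(OC)c(OC)cc3c2C(=O)[C@]2(OC)C=C[C@H]3N(C(=O)OCC(C)C)N2C(=O)OCC(C)C)cc1`: 47.9 ug/mL
Compound 2 `COc1cc2c(c(OCc3ccccc3F)c1OC)C(=O)[C@]1(OC)C=C[C@H]2N(C(=O)OCC(C)C)N1C(=O)OCC(C)C`: 109 ug/mL

Within the data shown here, in an ADME assay on KB cells (Homo sapiens) for cytotoxicity (on this read-out lower numbers stand for an effect already at smaller amounts and higher numbers for an effect only at larger amounts of compound), compound 2 has the higher of the two numbers so far, at 109 ug/mL. Compound 3 `COc1cc2c(c(O)c1OC)C(=O)[C@]1(OC)C=C[C@H]2N(C(=O)OCC(C)C)N1C(=O)OCC(C)C` differs from it by one change, (hydrogen in place of 2-fluorobenzyl on an oxygen on an aromatic ring), which reads (2-fluorobenzyl)oxy to hydroxy.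

Among the measured compounds shown here, only one measured step bears on this: a 2.3-fold higher number from compound 1 to compound 2 (0.36 log units; beyond the scatter). That modest step exchanges one aromatic ring for another on a saturated chain carbon, whereas compound 3 loses the whole 2-fluorobenzyl. For the measured compounds named here, no measured pair shows such a removal, so the direction is only weakly supported. With compound 2 at the top of the two numbers, a modest move towards a lower number is expected in this assay. The expected change is a 2.2-fold lower number from compound 2 to compound 3 (0.34 log units; beyond the scatter). Compound 3 is estimated at 50 ug/mL, with an expected range of 12 ug/mL to 170 ug/mL.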

Compound 3, concentration for half-maximal effect: > 300 ug/mL
Compound 3: only a limit was reported; the forecaster's own chance of this, stated with the estimate: 15%; middle value at least 6.0-fold (0.77 log units) from the limit.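

In this assay, compound 3 gives > 300 ug/mL, which is a limit of the assay and not a number. On the oxygen on the aromatic ring, hydrogen in place of 2-fluorobenzyl gives an at least 2.7-fold higher number from compound 2 to compound 3 (0.43 log units; beyond the scatter), and hydrogen in place of 4-methoxybenzyl gives an at least 6.2-fold higher number from compound 1 to compound 3 (0.79 log units; beyond the scatter). The earlier pair showed only a shift between two benzyl groups; among these three compounds, the free hydroxy compound stands higher than both benzyl ethers, so the lower numbers go with a benzyl group on this oxygen, and no compound shown goes against this.

Going by these compounds, the true size of both steps stays open, with only a limit for compound 3. Also open, on these data alone, is whether a methyl group or a longer alkyl chain on this oxygen would keep the lower numbers of compound 1 and compound 2.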